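The compounds below may be only part of what the source reports. "The series", "measured", "known", "first", "only" and "open" are said of these compounds alone.

In an ADME assay on HEL cells (Homo sapiens) for cytotoxicity, with a stated time of 3 days (on this read-out lower numbers stand for higher toxicity in this test and higher numbers for lower toxicity in this test), compound 1 `Cc1cc(-n2cccc2)c2ncc(CSCCc3ccccc3)n2c1` gives 26 ug/mL. Compound 2 `Cc1cc(-n2ccc3cccnc32)c2ncc(CSCCc3ccccc3)n2c1` gives > 100 ug/mL, which is a limit of the assay and not a number (the limit of > 100 ug/mL in this assay, at which 1 of the 2 values shown sits). The step of an at least 3.8-fold higher number from compound 1 to compound 2 (0.58 log units; beyond the scatter) therefore places compound 2 at the upper edge of the numbers shown. Compound 3 `Cc1cc(C#N)c2ncc(CSCCc3ccccc3)n2c1` differs from compound 2 by a group of 2 heavy atoms (1 carbon, 1 nitrogen; no ring) in place of a group of 9 heavy atoms (7 carbon, 2 nitrogen; one five-membered aromatic ring with 1 hetero atom, one six-membered aromatic ring with 1 hetero atom), on an aromatic carbon. For the measured compounds named here, the only measured step bearing on this change is the growth from compound 1 to compound 2, and removing the larger group is expected to reverse part of it. For compound 3 the expected step is an at least 2.0-fold lower number from compound 2 to compound 3 (0.30 log units; that floor lies within the scatter). Compound 3 is thus estimated at 50 ug/mL, between 15 ug/mL and 100 ug/mL.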

Compound 3, half-maximal cytotoxic concentration: > 100 ug/mL
Compound 3 gave a limit, no number (the forecaster's own chance of this, stated with the estimate: 35%); at least 2.0-fold (0.30 log units) between middle value and limit.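

Cyano in place of 1H-pyrrol-1-yl gives an at least 3.8-fold higher number from compound 1 to compound 3 (0.58 log units; beyond the scatter) in this assay. At this aromatic carbon, the higher number therefore does not require the larger fused group of compound 2, and of the three compounds only compound 1 has a readable value. The step between compound 2 and compound 3 cannot be read, and both compounds sit at the same limit: the limit of > 100 ug/mL in this assay, at which 2 of the 3 values shown sit.

From the compounds shown here alone, how far compound 2 and compound 3 lie past that limit remains open. Also open, going by these compounds, is where an amine or a carboxylic acid on this aromatic carbon would fall in this assay.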